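Series notes: bromo to methyl, compound 2 to compound 4

This account rests on a few compounds, and the source may have more. Where it says the series, first, only, none or still open, it means among the compounds named here.

Measured so far:
compound 1 `COc1ccc2cc(C(C)c3nnc4n3N=C(c3ccc(C(F)(F)F)cc3)CS4)ccc2c1` — 6900 nM
compound 2 `CC(C)Cc1ccc(C(C)c2nnc3n2N=C(c2ccc(Br)cc2)CS3)cc1` — 9400 nM
compound 3 `CC(c1ccc(-c2ccccc2)c(F)c1)c1nnc2n1N=C(c1ccc([N+](=O)[O-])cc1)CS2` — 7800 nM

In a functional assay on MCF7 cells (Homo sapiens) for inhibition, read by sulforhodamine B assay, with a stated time of 72 h (a lower number here means a stronger inhibitor, a higher number a weaker inhibitor), compound 2 gives 9400 nM, the highest of the three numbers, though compound 3 at 7800 nM and compound 1 at 6900 nM both lie within the usual scatter of it, so no order among the three can be read. Compound 4 `Cc1ccc(C2=Nn3c(nnc3C(C)c3ccc(CC(C)C)cc3)SC2)cc1` has not yet been measured; it differs from compound 2 in one place: methyl in place of bromo on an aromatic carbon. For the measured compounds named here, no measured pair in the set shows this change, so nothing here shows how a methyl in place of a bromo moves the numbers. The expected step is a 1.0-fold lower number from compound 2 to compound 4 (0.02 log units; within the scatter), that is, none beyond the scatter. Compound 4 is accordingly estimated at 9000 nM, with a range from 4000 nM to 20000 nM.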

Compound 4, half-maximal inhibitory concentration: 6300 nM
Beside the measured number, compound 4's estimate is 1.4-fold (0.15 log units) above it, within the range that was stated.
By their numbers in this assay, from the lowest: compounds 4, 1, 3 and 2 (each within the scatter of the next).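

Going from 4-bromophenyl to 4-methylphenyl gives a 1.5-fold lower number from compound 2 to compound 4 (0.17 log units; within the scatter). For the compounds shown here, this is the first pair for this change, and at this place it shows no shift beyond the scatter, so these numbers do not separate methyl from bromo. No evidence at hand bears on this step. Open, as far as these compounds go, is whether an amine, a carboxylic acid or a longer chain at this place would move the number beyond the scatter. Also open, from the compounds shown here alone, is whether methyl in place of bromo reads the same with the other side groups of compound 1 or compound 3.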